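Isopropyl in Place of Trifluoromethyl at a Permeability Limit

The source may hold more compounds than are shown below. What is called first, only, known or untested is meant among the compounds shown, and "the series" means these compounds.

Compound 3 `CNC(=O)c1cc(Oc2ccc3nc(Nc4ccc(C(F)(F)F)cc4)ncc3c2)ccn1` gives in an ADME assay on Caco-2 cells (Homo sapiens) for permeability, in the apical to basolateral direction (a higher number here means that the compound crosses the layer faster, a lower number that the compound crosses the layer more slowly), a reading of < 1 10^-6 cm/s, which is a limit of the assay and not a number. Compound 1 `CNC(=O)c1cc(Oc2ccc3nc(Nc4ccccc4)ncc3c2)ccn1` likewise gives in this assay a value of < 1 10^-6 cm/s, also a limit. Compound 2 `CNC(=O)c1cc(Oc2ccc3nc(Nc4ccc(Br)cc4)ncc3c2)ccn1` gives in this assay a value of < 1 10^-6 cm/s, again a limit. All three readings share (the limit of < 1 10^-6 cm/s in this assay, at which 3 of the 3 values shown sit), so the steps a step that the two limits leave unreadable from compound 1 to compound 2, a step that the two limits leave unreadable from compound 1 to compound 3 and a step that the two limits leave unreadable from compound 2 to compound 3 cannot be sized. Compound 4 `CNC(=O)c1cc(Oc2ccc3nc(Nc4ccc(C(C)C)cc4)ncc3c2)ccn1` differs from compound 3 by isopropyl in place of trifluoromethyl on an aromatic carbon. The three unreadable steps on the same aromatic carbon bear on this change, so no direction beyond the scatter is expected for a step that the limit leaves unreadable from compound 3 to compound 4. Compound 4 is therefore estimated at 0.7 10^-6 cm/s, with a range from 0.2 10^-6 cm/s to 3 10^-6 cm/s, most likely again reported only as a limit.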

Compound 4, apparent permeability: < 1 10^-6 cm/s
Compound 4: only a limit was reported; the forecaster's own chance of this, stated with the estimate: 65%; the middle value is on the limit's open side.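

In this assay, within the data shown here, compound 4 gives < 1 10^-6 cm/s, a limit and not a number, so no step among compound 1, compound 2, compound 3 and compound 4 can be read: the limit of < 1 10^-6 cm/s in this assay, at which 4 of the 4 values shown sit. The compounds shown leave open whether these four differ at all in this assay.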